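The source may hold more compounds than are shown below. What is called first, only, known or untested is meant among the compounds shown, and "the series" means these compounds.

Measured set in a functional assay on Jurkat cells (Homo sapiens); on this read-out lower numbers stand for stronger inhibition and higher numbers for weaker inhibition:
compound 1 `CC(C)[C@H](NC(=O)COc1cccc2ccccc12)C(=O)N[C@@H](CC(=O)O)C(=O)COC(=O)c1c(Cl)cccc1Cl`: 10600 nM
compound 2 `CC(C)[C@H](NC(=O)COc1cccc2ccccc12)C(=O)N[C@@H](CC(=O)O)C(=O)COc1cccc2ccccc12`: a limit only, > 100000 nM
compound 3 `CC(C)[C@H](NC(=O)COc1cccc2ccccc12)C(=O)N[C@@H](CC(=O)O)C(=O)COc1ccc(F)cc1`: a limit only, > 100000 nM

Compound 3 stands at the limit of this assay; no number is known for it, only that it lies beyond the range read. Compound 2 sits at the same limit, so (the limit of > 100000 nM in this assay, at which 2 of the 3 values shown sit). Within the data shown here, the only readable steps run from compound 1: an at least 9.4-fold higher number from compound 1 to compound 2 (0.97 log units; beyond the scatter) and an at least 9.4-fold higher number from compound 1 to compound 3 (0.97 log units; beyond the scatter). The remaining pair gives a step that the two limits leave unreadable from compound 2 to compound 3.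

Compound 4 `CC(C)[C@H](NC(=O)COc1cccc2ccccc12)C(=O)N[C@@H](CC(=O)O)C(=O)COc1c(F)c(F)c(F)c(F)c1F` differs from compound 3 by 2,3,4,5,6-pentafluorophenyl in place of 4-fluorophenyl on an oxygen on a saturated carbon. Among the measured compounds shown here, no measured step exchanges one fluorinated phenyl for another on that oxygen; both readable steps exchange the (2,6-dichlorophenyl)carbonyl for an aryl and both end at the limit. The shown steps give no ground for expecting a return below the limit, so compound 4 is expected to stay near it, with an estimate of 80000 nM and a range of 20000 nM to 300000 nM. The implied step an at least 1.2-fold lower number from compound 3 to compound 4 (0.09 log units; that floor lies within the scatter) is expected to be small and is read against a limit, not a number.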

Compound 4, half-maximal inhibitory concentration: 3050 nM
Estimate against measurement, compound 4: 26-fold (1.42 log units) above; measured number outside the range, below it.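

In this assay, an aryl on an oxygen on a saturated carbon does not in itself rule out a readable value: the 2,3,4,5,6-pentafluorophenyl gives an at least 32-fold lower number from compound 3 to compound 4 (1.51 log units; beyond the scatter) and an at least 32-fold lower number from compound 2 to compound 4 (1.51 log units; beyond the scatter). Both steps start from a limit and are floors, not sizes: the limit of > 100000 nM in this assay, at which 2 of the 4 values shown sit.

Exchanging the (2,6-dichlorophenyl)carbonyl for an aryl therefore need not cost inhibition, as a 3.5-fold lower number from compound 1 to compound 4 (0.54 log units; beyond the scatter) is a step between two numbers and goes the other way; the earlier loss holds for compound 2 and compound 3, while compound 4 goes against it.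

The step between compound 2 and compound 3 cannot be read, so these two aryl groups cannot be ordered. On these data alone, whether all the fluorines on the ring are required stays open, and a 2,3,5,6-tetrafluorophenyl or a 2,6-difluorophenyl on the same oxygen would test this.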